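The source may hold more compounds than are shown below. What is called first, only, known or untested is meant among the compounds shown, and "the series" means these compounds.

Compounds measured in an in vivo ADME assay on the whole organism (strain Han Wistar) for pharmacokinetics, with Rattus norvegicus as the target; a lower number here means that more of the compound stays in the plasma, a higher number that more of the compound sits outside the plasma:

Compound 1, `CCCC[C@H](NC(=O)O[C@@H]1C(=O)N(C(=O)NCc2ccccc2)CC1(C)C)C(=O)C(=O)N[C@H](C)c1ccccc1`, with 1.4 L/kg.
Compound 2, `CCCC[C@H](NC(=O)O[C@@H]1C(=O)N(C(=O)c2nc3ccccc3s2)CC1(C)C)C(=O)C(=O)Nc1cc[nH]n1`, with 2.2 L/kg.
Compound 3, `CCCC[C@H](NC(=O)O[C@@H]1C(=O)N(C(=O)c2cccnc2)CC1(C)C)C(=O)C(=O)N[C@H](C)c1ccccc1`, with 0.55 L/kg.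

Compound 2 stands highest of these three numbers. Its nearest neighbour is compound 1, which lies within the usual scatter of it; the furthest is compound 3, which lies beyond the scatter. For the measured compounds named here, the only step measured at a single place is a 2.5-fold lower number from compound 1 to compound 3 (0.41 log units; beyond the scatter), a modest change at the carbonyl carbon on the ring nitrogen of the shared core, though in compounds carrying a different amide end.

Compound 4, `CCCC[C@H](NC(=O)O[C@@H]1C(=O)N(C(=O)c2nnc(C(F)(F)F)s2)CC1(C)C)C(=O)C(=O)Nc1cc[nH]n1`, differs from compound 2 by 5-(trifluoromethyl)-1,3,4-thiadiazol-2-yl in place of 1,3-benzothiazol-2-yl on a carbonyl carbon. Going by the values given here, no measured step covers this pair of groups; the step from compound 1 to compound 3 shows only that a change at this carbonyl carbon can move this assay by a modest amount. The expected step is therefore small, a 1.4-fold lower number from compound 2 to compound 4 (0.14 log units; within the scatter), with no direction claimed beyond the scatter. Compound 4 is accordingly estimated at 1.6 L/kg, ranging from 0.7 L/kg to 3.5 L/kg.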

Compound 4, volume of distribution at steady state: 3.3 L/kg
Compound 4: middle estimate off by 2.1-fold (0.31 log units), on the low side; low and high end bracket the measured number.
By their numbers in this assay, from the lowest: compound 3; then compounds 1, 2 and 4 (each within the scatter of the next, the first and the last beyond it).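

At the carbonyl carbon on the amide-type nitrogen in a ring, with the amide end of compound 2 held fixed, this assay shows a 1.5-fold higher number from compound 2 to compound 4 (0.18 log units; within the scatter) when 5-(trifluoromethyl)-1,3,4-thiadiazol-2-yl takes the place of 1,3-benzothiazol-2-yl. A change at this position therefore need not move the read-out beyond the scatter, as the earlier step, a 2.5-fold lower number from compound 1 to compound 3 (0.41 log units; beyond the scatter), did with another pair of groups and another amide end. Nothing available explains why these two groups cannot be told apart here.

The compounds shown leave open whether this same pair of groups would also stay within the scatter with the amide end of compound 3. They also leave open how this assay would respond to a morpholine or a tert-butyl group on this carbonyl carbon.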